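Swapping an Amide Side Chain for a Ring Amine

This account rests on a few compounds, and the source may have more. Where it says the series, first, only, none or still open, it means among the compounds named here.

Of the compounds shown here, two built on a shared core have been measured in a functional assay on HEK293 cells for antagonist activity at transient receptor potential cation channel subfamily V member 1 (Homo sapiens), read by FLIPR and calcium flux; a higher number here means a weaker inhibitor, a lower number a stronger inhibitor. Compound 1 `CCC(CC)N1CCN(c2nc3c(c(Nc4ccc(C(F)(F)F)cc4)n2)CCN(c2ncccc2C(F)(F)F)CC3)CC1` gives 41 nM. For the measured compounds named here, compound 2 `CC(=O)NC1CCN(c2nc3c(c(Nc4ccc(C(F)(F)F)cc4)n2)CCN(c2ncccc2C(F)(F)F)CC3)C1` gives 150 nM, the highest of the two numbers; its only neighbour is compound 1, and the single measured step, a 3.7-fold higher number from compound 1 to compound 2 (0.56 log units; beyond the scatter), separates them. The unmeasured compound 3 `FC(F)(F)c1ccc(Nc2nc(NC3CCCNC3)nc3c2CCN(c2ncccc2C(F)(F)F)CC3)cc1` differs from compound 2 in one place: (piperidin-3-yl)amino in place of 3-acetamidopyrrolidin-1-yl on an aromatic carbon. Going by the values given here, no measured step covers exactly this exchange. Among the compounds with values here, the one step available, from compound 1 to compound 2, replaced a 4-(pentan-3-yl)piperazin-1-yl group with a 3-acetamidopyrrolidin-1-yl group and raised the number modestly. Compound 3 removes that acetamide-bearing ring again and brings in a six-membered ring with a ring nitrogen carrying a hydrogen, so the number for compound 3 is expected to move back toward compound 1, by an estimated step of a 2.1-fold lower number from compound 2 to compound 3 (0.33 log units; beyond the scatter) in this assay. The estimate for compound 3 in this assay is 70 nM, expected to fall within the range 25 nM to 250 nM.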

Compound 3, half-maximal inhibitory concentration in the transient receptor potential cation channel subfamily V member 1 assay: > 5000 nM
Compound 3 was reported as a limit; the forecaster's own chance of this, stated with the estimate: 3%; middle value at least 71-fold (1.85 log units) away from the limit.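

At this position, on an aromatic carbon between two ring nitrogen atoms, the earlier compounds had shown only a modest change, whereas in the transient receptor potential cation channel subfamily V member 1 assay putting (piperidin-3-yl)amino in place of 3-acetamidopyrrolidin-1-yl gives an at least 33-fold higher number from compound 2 to compound 3 (1.52 log units; beyond the scatter). Measured against 4-(pentan-3-yl)piperazin-1-yl, the same group in the transient receptor potential cation channel subfamily V member 1 assay gives an at least 120-fold higher number from compound 1 to compound 3 (2.08 log units; beyond the scatter), so a change at this one carbon can matter far more than the first step suggested. Compound 3 is reported only as a limit and not as a number, so both of these steps are floors: the limit of > 5000 nM in the transient receptor potential cation channel subfamily V member 1 assay, at which 1 of the 3 values shown sits.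

In a physicochemical assay for solubility, in phosphate buffer, measured as thermodynamic solubility, at pH 2 (on this read-out higher numbers stand for higher solubility and lower numbers for lower solubility), compound 2 gives 202 ug/mL. Going by these compounds, in the physicochemical assay compound 3 gives > 235 ug/mL, which is also a limit and not a number, and the step there cannot be read: the limit of > 235 ug/mL in the physicochemical assay, at which 1 of the 2 values shown sits. Whether the large loss belongs to the amino link or to the ring nitrogen carrying a hydrogen stays open, and a piperidin-1-yl group at this carbon, or a methyl group on the ring nitrogen of the (piperidin-3-yl)amino group, would help to separate the two.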